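The compounds below may be only part of what the source reports. "The series", "measured", "known", "first", "only" and "open" are said of these compounds alone.

Measured so far:
compound 1 `C/C(=N\NC(=O)COc1cccc2ccccc12)c1cccc([N+](=O)[O-])c1`, 20 ug/mL
compound 2 `C/C(=N\NC(=O)COc1cccc2ccccc12)c1ccccc1Br`, 20 ug/mL

Both numbers come from an ADME assay on HEL cells (Homo sapiens) for cytotoxicity; on this read-out lower numbers stand for higher toxicity in this test and higher numbers for lower toxicity in this test. In this assay compound 1 gives 20 ug/mL and compound 2 gives 20 ug/mL, so compound 2 stands level with compound 1, and the step of no change at the digits printed from compound 1 to compound 2 (within the scatter) shows no change beyond the scatter. That step put 2-bromophenyl in place of 3-nitrophenyl on a carbon with a double bond to nitrogen, and the read-out did not move.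

Compound 3 `C/C(=N\NC(=O)COc1cccc2ccccc12)c1ccc(Cl)cc1` has not been measured yet. It differs from compound 2 in one place: 4-chlorophenyl in place of 2-bromophenyl on a carbon with a double bond to nitrogen. Once more one halogen-bearing ring replaces another on the carbon with a double bond to nitrogen of the shared core. Within the data shown here, the only measured step that bears on such a change is no change at the digits printed from compound 1 to compound 2 (within the scatter), and it was flat; no other pair tests this part of the molecule. For compound 3 the expected step is therefore no change at the digits printed from compound 2 to compound 3 (within the scatter), within the scatter and with no direction preferred. In this assay compound 3 is estimated to give 20 ug/mL, with a likely range from 10 ug/mL to 40 ug/mL.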

Compound 3, minimum cytotoxic concentration: >= 4 ug/mL
Compound 3 ended at the assay's limit; the forecaster's own chance of this, stated with the estimate: 10%; the middle value does not contradict the limit.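

In this assay compound 3 gives >= 4 ug/mL, which is a limit of the assay and not a number. No step from compound 1 or compound 2 to compound 3 can therefore be read: the limit of >= 4 ug/mL in this assay, at which 1 of the 3 values shown sits.

The compounds shown leave open whether 4-chlorophenyl, in place of 2-bromophenyl or 3-nitrophenyl, moves the read-out at all, and in which direction.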